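A few compounds are considered here, and "the series" means these few. Any claim that something is new, unique, unknown or untested is made for them only; others in the source may bear on it.

Measured in an ADME assay on MDCK cells (Canis lupus familiaris) for cytotoxicity, read by CCK-8 assay, with a stated time of 5 days; on this read-out lower numbers stand for higher toxicity in this test and higher numbers for lower toxicity in this test:
- compound 1 `O=C(O)[C@H]1C2CCC(CC2)[C@@H]1Nc1nc(-c2c[nH]c3ncc(F)cc23)nc2ccsc12`: 1500 nM
- compound 2 `N#Cc1csc2c(N[C@H]3C4CCC(CC4)[C@@H]3C(=O)O)nc(-c3c[nH]c4ncc(F)cc34)nc12`: 700 nM
- compound 3 `O=C(O)[C@H]1C2CCC(CC2)[C@@H]1Nc1nc(-c2c[nH]c3ncc(F)cc23)nc2c1S(=O)(=O)CC2`: > 50000 nM (a limit of the assay, not a number)

Among the compounds with values here, of the two plain numbers, the one for compound 1 is the higher. For compound 3 there is only (the limit of > 50000 nM in this assay, at which 1 of the 3 values shown sits), so no step can be read from it.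

Compound 4 `O=C(O)[C@H]1C2CCC(CC2)[C@@H]1Nc1nc(-c2n[nH]c3ncc(F)cc23)nc2ccsc12` differs from compound 1 in one group, attached on an aromatic carbon between two ring nitrogen atoms: a group of 10 heavy atoms (6 carbon, 3 nitrogen, 1 fluorine; one five-membered aromatic ring with 2 hetero atoms, one six-membered aromatic ring with 1 hetero atom) in place of a group of 10 heavy atoms (7 carbon, 2 nitrogen, 1 fluorine; one five-membered aromatic ring with 1 hetero atom, one six-membered aromatic ring with 1 hetero atom), on an aromatic carbon. The six-membered aromatic ring with 1 hetero atom stays, while the five-membered aromatic ring goes from 1 hetero atom to 2.

Within the data shown here, no measured step changes this group. The nearest guide is the swap of cyano in place of hydrogen on an aromatic carbon, which gave a 2.1-fold lower number from compound 1 to compound 2 (0.33 log units; beyond the scatter). That swap happens at a different place, so it suggests a size for a small change but no direction. In this assay, going by these compounds, a step of about that size is therefore expected, and its direction remains open, with only a slight lean towards a higher number. The expected step is a 1.3-fold higher number from compound 1 to compound 4 (0.12 log units; within the scatter). Compound 4 is estimated at 2000 nM, with an expected range of 700 nM to 8000 nM.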

Compound 4, half-maximal cytotoxic concentration: 200 nM
Beside the measured number, compound 4's estimate is 10-fold (1.00 log units) above it; the whole stated range lies above it.
By their numbers in this assay, from the lowest: compound 4; then compound 2; then compound 1. At a limit, above all of these: compound 3.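

Adding one ring nitrogen to the five-membered aromatic ring, while the group keeps the same number of heavy atoms, gives a 7.5-fold lower number from compound 1 to compound 4 (0.88 log units; beyond the scatter) in this assay; a lower number here means higher toxicity in this test. The aromatic carbon between two ring nitrogen atoms therefore carries a group whose exact ring atoms matter, as this small swap moves the read-out further than the other step available from compound 1, which is a 2.1-fold lower number from compound 1 to compound 2 (0.33 log units; beyond the scatter) and is made at a different place. Nothing measured among these compounds bears on why one extra ring nitrogen has this effect.

Going by these compounds, compound 3 stands at > 50000 nM, which is a limit of the assay and not a number, so it remains open whether the same ring swap would also lower the read-out on that changed core. It is equally unknown whether the step would repeat on the nitrile-bearing compound 2, or whether chlorine in place of the fluorine on the entering group would shift the number in either direction.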